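A few compounds are considered here, and "the series" means these few. Any claim that something is new, unique, unknown or untested is made for them only; others in the source may bear on it.

Measured compounds:

Compound 1, `COC(=O)c1cc(=O)c2c(OC)cc(OC)cc2[nH]1`: 16100 nM
Compound 2, `COC(=O)c1cc(=O)c2cc(N)ccc2[nH]1`: > 67200 nM (a limit)
Compound 3, `COc1ccc(-c2cc(=O)c3c(OC)cc(OC)cc3n2S(=O)(=O)c2ccc(C#N)cc2)cc1`: 7900 nM

All three were examined in a functional assay on SUP-B15 cells (Homo sapiens) for antiproliferative activity, with a stated time of 72 h; a higher number here means that more compound is needed for the effect, a lower number that less compound is needed. Compound 1 gives 16100 nM in this assay. For compound 2 the assay reports only a limit, > 67200 nM, and no number. Compound 3 gives 7900 nM, the lowest of the two numbers shown; the number for compound 1 lies above it by a margin beyond the usual scatter. The remaining value is the limit of > 67200 nM in this assay, at which 1 of the 3 values shown sits.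

The untested compound 4, `COc1ccc(-c2cc(=O)c3c(OC)cc(OC)cc3n2S(=O)(=O)c2ccc(Br)s2)cc1`, differs from compound 3 only at the sulfonyl group on the ring nitrogen: 5-bromothiophen-2-yl in place of 4-cyanophenyl on a sulfonyl sulfur. Among the measured compounds shown here, no pair of measured compounds in this set differs in one place, so nothing here directly calibrates such an exchange. Since both the leaving and the entering group are aromatic substituents carried on the same sulfonyl sulfur, the change from compound 3 to compound 4 is expected to stay within the scatter, that is a 1.0-fold higher number from compound 3 to compound 4 (0.01 log units; within the scatter). Compound 4 is therefore estimated at 8000 nM, with a range from 3000 nM to 25000 nM.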

Compound 4, half-maximal effective concentration: > 48200 nM
Compound 4: no number, only a limit; the forecaster's own chance of this, stated with the estimate: 10%; at least 6.0-fold (0.77 log units) between middle value and limit.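

In this assay, exchanging the 4-cyanophenyl group on the sulfonyl sulfur for a 5-bromothiophen-2-yl group gives an at least 6.1-fold higher number from compound 3 to compound 4 (0.78 log units; beyond the scatter). Among the compounds shown here, this is the first step in the set measured across a single place, and it shows that the result at this position depends on which aromatic group the sulfonyl sulfur carries, so these two groups are not interchangeable here. Compound 4 reaches only a limit of the assay, not a number: the limit of > 48200 nM in this assay, at which 1 of the 4 values shown sits.

From the compounds shown here alone, the true size of the step stays open, as does which part of the exchange counts: the ring, the bromine or the nitrile. Also open, going by these compounds, is how a plain phenyl, a thiophen-2-yl without bromine or a simple methyl on the sulfonyl sulfur would read in this assay.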